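Methoxy in place of hydrogen: cytotoxicity check

The compounds below may be only part of what the source reports. "The series", "measured", "known", "first", "only" and "open" are said of these compounds alone.

Measured so far:
- compound 1, `c1ccc(-c2ccc(Cn3cncc3CNc3cccc(-c4ccccc4)c3)cc2)cc1`: 10000 nM
- compound 2, `O=[N+]([O-])c1ccc(Cn2cncc2CNc2cccc(-c3ccccc3)c2)cc1`: 10000 nM

In a toxicity assay on NIH3T3 cells (Mus musculus) for cytotoxicity, read by resazurin assay (on this read-out lower numbers stand for an effect already at smaller amounts and higher numbers for an effect only at larger amounts of compound), compound 1 gives 10000 nM. Compound 2 gives 10000 nM in this assay. Among the measured compounds shown here, the only measured step, no change at the digits printed from compound 1 to compound 2 (within the scatter), is a swap of nitro in place of phenyl on an aromatic carbon, and it leaves the read-out within the scatter. Compound 1 therefore stands level with compound 2; nothing in the pair separates the two.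

Compound 3, `COc1ccc(NCc2cncn2Cc2ccc(-c3ccccc3)cc2)cc1-c1ccccc1`, has not yet been measured in this assay. Against compound 1 it shows (methoxy in place of hydrogen on an aromatic carbon). For the measured compounds named here, no measured step touches a methoxy, nor the aromatic carbon it enters. Going by the values given here, the one step available shows that a substantial change on a distant aromatic carbon moved nothing in this assay, and a far smaller addition is expected to do likewise. The expectation for compound 3 is therefore no step beyond the scatter, written as no change at the digits printed from compound 1 to compound 3 (within the scatter). Compound 3 is estimated at 10000 nM, with a range from 5000 nM to 20000 nM.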

Compound 3, half-maximal effective concentration: > 1000 nM
Compound 3 was reported as a limit (the forecaster's own chance of this, stated with the estimate: 30%); the middle value is on the limit's open side.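

In this assay compound 3 is reported as a limit, > 1000 nM, and the step to it from compound 1 cannot be read: the limit of > 1000 nM in this assay, at which 1 of the 3 values shown sits. The compounds shown leave open whether methoxy in place of hydrogen on an aromatic carbon changes this read-out at all, and if so, by how much.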